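From Piperazine to Pyridine: What to Expect of Compound 3

The compounds below may be only part of what the source reports. "The series", "measured", "known", "first", "only" and "open" are said of these compounds alone.

Two measured compounds share one core and differ in a single group on an aromatic carbon. Compound 1 `CCCn1ccc2cc(N3CCC(O)CC3)cc(Cl)c2c1=O` carries a 4-hydroxypiperidin-1-yl group; in a functional assay on CHO cells for agonist activity at metabotropic glutamate receptor 2 (Homo sapiens), read by GTPgammaS binding (a higher number here means that more compound is needed for the effect, a lower number that less compound is needed), compound 1 gives 5010 nM. Compound 2 `CCCn1ccc2cc(N3CCNCC3)cc(Cl)c2c1=O` carries a piperazin-1-yl group in its place. For compound 2 this assay reports only a limit, > 10000 nM, not a number. The step of an at least 1.9-fold higher number from compound 1 to compound 2 (0.30 log units; that floor lies within the scatter) is therefore a floor rather than a measured size, and it rests on (the limit of > 10000 nM in this assay, at which 1 of the 2 values shown sits). Compound 3 `CCCn1ccc2cc(-c3ccncc3)cc(Cl)c2c1=O` takes the change one stage further: pyridin-4-yl in place of piperazin-1-yl on an aromatic carbon. For the measured compounds named here, only one measured step touches this position, and it ends at a limit, so it offers little guidance. Compound 3 is expected to remain weak, with an estimated step of an at least 1.2-fold lower number from compound 2 to compound 3 (0.09 log units; that floor lies within the scatter) that stays within the scatter. Compound 3 is estimated at 8000 nM, with a range from 2000 nM to 30000 nM, and a real chance that only a limit is reported again.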

Compound 3, half-maximal effective concentration: 1260 nM
Estimate against measurement, compound 3: 6.3-fold (0.80 log units) above; the measured number lies below the stated range.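

Among the compounds shown, a six-membered aromatic ring at this position gives a lower number in this assay than either non-aromatic ring, the first sign that a change here can lower the number rather than leave it at a limit. Against the piperazin-1-yl group the result is an at least 7.9-fold lower number from compound 2 to compound 3 (0.89 log units; beyond the scatter), and against the 4-hydroxypiperidin-1-yl group it is a 4.0-fold lower number from compound 1 to compound 3 (0.60 log units; beyond the scatter), so compound 3 stands beyond the scatter from both. Only the second of these steps has a measured size, and the first remains a floor: the limit of > 10000 nM in this assay, at which 1 of the 3 values shown sits.

What the compounds shown leave open is whether the ring nitrogen of pyridin-4-yl matters at all. A plain phenyl ring or a pyridin-3-yl group at this position would test that, and a simple morpholine ring would extend the comparison among the non-aromatic rings.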